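Swapping 2,4-dichlorophenyl for 4-methoxyphenyl on a shared core

The source may hold more compounds than are shown below. What is called first, only, known or untested is meant among the compounds shown, and "the series" means these compounds.

Compound 1 (`COC(=O)/C(=C/c1ccccc1)CN1C(=O)[C@@H](OC)[C@H]1c1ccccc1C(F)(F)F`), compound 2 (`COC(=O)/C(=C/c1ccccc1)CN1C(=O)[C@@H](OC)[C@H]1c1ccc(F)cc1`), compound 3 (`COC(=O)/C(=C/c1ccccc1)CN1C(=O)[C@@H](OC)[C@H]1c1ccc(Cl)cc1Cl`) and compound 4 (`COC(=O)/C(=C/c1ccccc1)CN1C(=O)[C@@H](OC)[C@H]1c1ccc(OC)cc1`) share one core and differ only in the aromatic group on a saturated ring carbon. For the measured compounds named here, in a functional assay on MCF7 cells (Homo sapiens) for antiproliferative activity, read by MTT assay, with a stated time of 48 h (a higher number here means a weaker inhibitor, a lower number a stronger inhibitor), compound 2 gives 15600 nM as the only number available so far. In this assay, as far as these compounds go, the entry for compound 3 reads no result reported and the entry for compound 1 reads no result reported, so neither has a single number and how compound 3 ranks against compound 2 is unknown.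

The step followed here leads from compound 3 to compound 4 and puts 4-methoxyphenyl in place of 2,4-dichlorophenyl on a saturated ring carbon of a four-membered non-aromatic ring with 1 nitrogen (4-methoxyphenyl in place of 2,4-dichlorophenyl on a saturated ring carbon). Going by the values given here, no measured pair in this small set shows what such a swap does, and without a number for compound 3 the step itself cannot be sized. The expectation in this assay therefore rests on compound 2 at 15600 nM as the sole reference, with no shift beyond the scatter in either direction, though with wide uncertainty. Compound 4 is expected at 14000 nM in an estimated range from 4000 nM to 50000 nM in this assay.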

Compound 4, half-maximal inhibitory concentration: 11600 nM
The estimate for compound 4 lay 1.2-fold (0.08 log units) above the measured number; low and high end bracket the measured number.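

With compound 4, this position has its first readable step: in this assay the aromatic group on the saturated ring carbon gives a 1.3-fold lower number from compound 2 to compound 4 (0.13 log units; within the scatter) with methoxy in place of fluoro on an aromatic carbon. Between these two compounds, the change of substituent on the aromatic ring therefore leaves the antiproliferative read-out within the usual scatter, so the two cannot be told apart in this assay. The step that puts 4-methoxyphenyl in place of 2,4-dichlorophenyl cannot be read, and neither can any step involving compound 1, since neither compound 3 nor compound 1 has a single number. Nothing available here offers an explanation for how close the two measured compounds lie.

What the compounds shown leave open is whether 2,4-dichlorophenyl or the trifluoromethyl-bearing aromatic group stands apart from the two measured compounds in this assay at all. As far as these compounds go, it also remains open whether an amine or a carboxylic acid on the aromatic ring, or a longer chain in place of the methoxy group, would move the number beyond the scatter.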